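Swapping the thiophene for a trifluoromethylphenyl on the shared core

A few compounds are considered here, and "the series" means these few. Any claim that something is new, unique, unknown or untested is made for them only; others in the source may bear on it.

Among the measured compounds shown here, compound 2 `c1csc(-c2cn3ccnc3c(-c3ccc4ncn(C5CCCCC5)c4c3)n2)c1` gives the higher of the two numbers so far: in a functional assay on HCT-116 cells (Homo sapiens) for inhibition, read by sulforhodamine B assay, with a stated time of 48 h, tested at 10 uM (on this read-out lower numbers stand for less inhibition and higher numbers for more inhibition at the one concentration tested (going by the name of the read-out)), compound 2 shows 21.1%, while compound 1 `Clc1ccc(-c2cn3ccnc3c(-c3ccc4ncn(C5CCCCC5)c4c3)n2)cc1` shows 7.34%. Compound 3 `FC(F)(F)c1cccc(-c2cn3ccnc3c(-c3ccc4ncn(C5CCCCC5)c4c3)n2)c1` differs from compound 2 by 3-(trifluoromethyl)phenyl in place of thiophen-2-yl on an aromatic carbon. For the measured compounds named here, the only measured step that bears on this, a number 13.8 percentage points higher from compound 1 to compound 2 (beyond the scatter), went from a six-membered ring of carbon only to thiophen-2-yl; compound 3 moves back to a six-membered ring of carbon only, so a modest drop is expected, a number 11.1 percentage points lower from compound 2 to compound 3 (beyond the scatter). For compound 3 the estimate is 10%, in a range from 0% to 25%.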

Compound 3, a percentage reported as inhibition, at one concentration (the size of the read-out at that concentration, not a potency): 17.6%
The estimate for compound 3 lay 7.6 percentage points below the measured number; low and high end bracket the measured number.
By their numbers in this assay, from the lowest: compound 1; then compounds 3 and 2 (each within the scatter of the next).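

In this assay, the change shows a number 3.5 percentage points lower from compound 2 to compound 3 (within the scatter), so at this place on the shared core 3-(trifluoromethyl)phenyl and thiophen-2-yl cannot be told apart. A six-membered aromatic ring of carbon only therefore does not always give a number as low as that of compound 1, as the other change shows a number 10.3 percentage points higher from compound 1 to compound 3 (beyond the scatter). No measurement here gives a reason for these numbers. Going by these compounds, what an amine or a carboxylic acid at this place would give remains open.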